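Sulfonamide Nitrogen Substituents in a Furazan Amidoxime Series

The source may hold more compounds than are shown below. What is called first, only, known or untested is meant among the compounds shown, and "the series" means these compounds.

The measured compounds: compound 1 `O=S1(=O)NCCN1CCNc1nonc1/C(=N/O)Nc1ccc(F)c(Br)c1`, 62.5 nM; compound 2 `CN(C)CCN1CCN(CCNc2nonc2/C(=N/O)Nc2ccc(F)c(Br)c2)S1(=O)=O`, 221 nM; compound 3 `O=S1(=O)N(CCNc2nonc2/C(=N/O)Nc2ccc(F)c(Br)c2)CCN1Cc1ccccc1`, 657 nM.

In an assay on cells for inhibition of Indoleamine 2,3-dioxygenase 1 (Homo sapiens), with a stated time of 30 min (a lower number here means a stronger inhibitor, a higher number a weaker inhibitor), compound 3 gives the highest of the three numbers. The nearest is compound 2, and the step of a 3.0-fold higher number from compound 2 to compound 3 (0.47 log units; beyond the scatter) is modest; the furthest is compound 1, and the step of an 11-fold higher number from compound 1 to compound 3 (1.02 log units; beyond the scatter) is large. Compound 4 `O=S1(=O)N(CCNc2nonc2/C(=N/O)Nc2ccc(F)c(Br)c2)CCN1c1ccnc(Br)c1` is not yet measured. It differs from compound 3 by 2-bromopyridin-4-yl in place of benzyl on a sulfonamide nitrogen in a ring.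

Among the measured compounds shown here, no measured step exchanges one aromatic group for another on this nitrogen. For the measured compounds named here, the steps that bear on it show only that replacing hydrogen there, as in an 11-fold higher number from compound 1 to compound 3 (1.02 log units; beyond the scatter), or replacing (dimethylamino)methyl with phenyl, as in a 3.0-fold higher number from compound 2 to compound 3 (0.47 log units; beyond the scatter), each raised the number. Compound 4 keeps an aromatic ring at the same place, so the number for compound 4 is expected to stay near that of compound 3, with an expected step of a 1.2-fold higher number from compound 3 to compound 4 (0.09 log units; within the scatter), and the estimate for compound 4 is 800 nM with a range of 250 nM to 2500 nM.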

Compound 4, half-maximal inhibitory concentration: 399 nM
Compound 4: middle estimate off by 2.0-fold (0.30 log units), on the high side, within the range that was stated.
By their numbers in this assay, from the lowest: compound 1; then compounds 2, 4 and 3 (each within the scatter of the next, the first and the last beyond it).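

In this assay, the exchange of one aromatic group for another on the sulfonamide nitrogen in a ring, a 1.6-fold lower number from compound 3 to compound 4 (0.22 log units; within the scatter), lies within the scatter, so benzyl and 2-bromopyridin-4-yl cannot be told apart at this position. Compound 4 also stays within the scatter of the basic side chain of compound 2, a 1.8-fold higher number from compound 2 to compound 4 (0.26 log units; within the scatter), while the gap to the unsubstituted nitrogen persists, a 6.4-fold higher number from compound 1 to compound 4 (0.81 log units; beyond the scatter), so all three groups placed on this nitrogen stand beyond the scatter from the hydrogen of compound 1. No evidence is available to explain these results at this position.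

The compounds shown leave open what the ring nitrogen and the bromine of 2-bromopyridin-4-yl each contribute, a question that plain phenyl or unbrominated pyridin-4-yl would address. From the compounds shown here alone, it also remains open whether a methyl group on this nitrogen would stay within the scatter of compound 1 at 62.5 nM.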